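The compounds below may be only part of what the source reports. "The series", "measured", "known", "first", "only" and "open" are said of these compounds alone.

For the measured compounds named here, compound 2 `COc1ccc(S(=O)(=O)NCCN2CCC(CCC(=O)c3cc(Cl)c(N)cc3OC)CC2)cc1Br` gives 24.3 nM in an assay on brain for displacement of a labelled ligand from 5-hydroxytryptamine receptor 4 (Cavia porcellus), with a stated time of 30 min, in the presence of a further agent that is not named here (a lower number here means a stronger inhibitor, a higher number a weaker inhibitor), the highest of the three numbers measured so far. Compound 1 `COc1ccc(S(=O)(=O)NCCN2CCC(CCC(=O)c3cc(Cl)c(N)cc3OC)CC2)cc1Cl` gives 22.5 nM, and compound 3 `COc1ccc(S(=O)(=O)NCCN2CCC(CCC(=O)c3cc(Cl)c(N)cc3OC)CC2)cc1OC` gives 8.2 nM. The step of a 1.1-fold higher number from compound 1 to compound 2 (0.03 log units; within the scatter) lies within the scatter, whereas a 3.0-fold lower number from compound 2 to compound 3 (0.47 log units; beyond the scatter) and a 2.7-fold lower number from compound 1 to compound 3 (0.44 log units; beyond the scatter) are both modest and beyond it. Compound 4 `COc1cc(N)c(Cl)cc1C(=O)CCC1CCN(CCNS(=O)(=O)c2ccc(NC(C)=O)cc2)CC1` differs from compound 2 by 4-acetamidophenyl in place of 3-bromo-4-methoxyphenyl on a sulfonyl sulfur. All three measured steps concern the same aryl ring on the sulfonyl sulfur, but each exchanges a single substituent, and none introduces an acetamido group or removes the methoxy. They therefore bear only loosely on this change. The halogen-to-methoxy exchanges moved the number by a modest amount at most, and a change of both substituents at once leaves the direction open. The expectation is a number near that of compound 2 or somewhat higher, with wide uncertainty. Compound 4 is estimated at 35 nM, within a range of 9 nM to 140 nM, which corresponds to an expected step of a 1.4-fold higher number from compound 2 to compound 4 (0.16 log units; within the scatter).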

Compound 4, inhibition constant: 7.7 nM
Compound 4: middle estimate off by 4.5-fold (0.66 log units), on the high side; measured number outside the range, below it.
By their numbers in this assay, from the lowest: compounds 4 and 3 (each within the scatter of the next); then compounds 1 and 2 (each within the scatter of the next).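

In this assay, the sulfonyl sulfur accepts a 4-acetamidophenyl group that carries neither the halogen nor the methoxy of the earlier rings, with (a 3.2-fold lower number from compound 2 to compound 4 (0.50 log units; beyond the scatter)) and (a 2.9-fold lower number from compound 1 to compound 4 (0.47 log units; beyond the scatter)). The new ring and 3,4-dimethoxyphenyl stand level (a 1.1-fold lower number from compound 3 to compound 4 (0.03 log units; within the scatter)), so among these four compounds the two rings without a halogen both give lower numbers than the two with bromo or chloro, and none goes against this. Nothing given here accounts for this pattern.

Because two substituents change at once, the compounds shown cannot separate the gain from adding the acetamido group from that of losing the halogen and methoxy. Going by these compounds, it also remains open how a free amine or a carboxylic acid in place of the acetamido group would fare.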